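Triazole aryl swap on a spirooxindole antiproliferative series

The source may hold more compounds than are shown below. What is called first, only, known or untested is meant among the compounds shown, and "the series" means these compounds.

Measured compounds:
compound 1, `Cc1cccc(-n2nncc2CN2C(=O)C3(C(C#N)=C(N)Oc4c(N)cc5nc6ccccc6nc5c43)c3ccccc32)c1`, which in an ADME assay on L02 cells (Homo sapiens) for antiproliferative activity, read by MTT assay, with a stated time of 48 h (a lower number here means a stronger inhibitor, a higher number a weaker inhibitor), gives > 50000 nM, a limit of the assay.
compound 2, `N#CC1=C(N)Oc2c(N)cc3nc4ccccc4nc3c2C12C(=O)N(Cc1cnnn1-c1ccc(F)cc1)c1ccccc12`, which in this assay gives > 50000 nM, again a limit.

Among the measured compounds shown here, compound 2 stands only at a limit in this assay, with no number of its own, and the one further value shown, that of compound 1, is a limit too. The step that the two limits leave unreadable from compound 1 to compound 2 therefore cannot be read; both values sit at the limit of > 50000 nM in this assay, at which 2 of the 2 values shown sit.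

Compound 3 is `N#CC1=C(N)Oc2c(N)cc3nc4ccccc4nc3c2C12C(=O)N(Cc1cnnn1-c1cccc(Br)c1)c1ccccc12`. It differs from compound 2 by 3-bromophenyl in place of 4-fluorophenyl on an aromatic nitrogen. For the measured compounds named here, the only measured step that bears on this change is the one from compound 1 to compound 2, which swaps one aryl group on the same triazole nitrogen and leaves both compounds at the limit, so nothing beyond the scatter is indicated for an aryl swap at this place. Compound 3 is accordingly expected to remain at or near the limit, with an estimated step of a number no higher from compound 2 to compound 3 (the limit leaves the size open). The estimate for compound 3 in this assay is 50000 nM, in the range from 25000 nM to 100000 nM.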

Compound 3, half-maximal inhibitory concentration: > 50000 nM
Compound 3: only a limit was reported; the forecaster's own chance of this, stated with the estimate: 85%; the middle value lies on the limit itself.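

In this assay compound 3 gives > 50000 nM, a limit of the assay. No new step can be read among compound 1, compound 2 and compound 3, since all three stand at a limit: the limit of > 50000 nM in this assay, at which 3 of the 3 values shown sit. The compounds shown leave open whether the aryl group on the triazole nitrogen makes any difference to the read-out.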